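The source may report more compounds than this note shows. Statements on the series, on what has been measured and on what is new or still open speak of the compounds shown alone.

Compound 1 `CCCCC(CCCC(=O)NO)CCC(=O)Nc1ccccc1` is the simplest member of the pair measured so far; in an assay on isolated protein for inhibition of histone deacetylase 8 (Homo sapiens), read by ELISA (a lower number here means a stronger inhibitor, a higher number a weaker inhibitor), compound 1 gives 430 nM. Compound 2 `CCCCCCC(CCCC(=O)NO)CCC(=O)Nc1ccccc1` carries an ethyl in place of hydrogen on a saturated chain carbon, seven bonds along the chain from a carbonyl carbon, and in this assay compound 2 gives 420 nM. The step of a 1.0-fold lower number from compound 1 to compound 2 (0.01 log units; within the scatter) is the only one available, and it shows that adding to the branch at that chain carbon left the number where it was. Compound 2 stands at the lower of the two numbers, within the scatter of compound 1, so neither is distinguished.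

Compound 3 `O=C(CCCC(CCC(=O)Nc1ccccc1)Cc1ccccc1)NO` is the next one to go into this assay. Relative to compound 2 the change is phenyl in place of pentyl on a saturated chain carbon, four bonds along the chain from a carbonyl carbon. Within the data shown here, no measured step touches this place or exchanges a chain for an aromatic ring, so the only guidance is the indifference of the single branch variation seen so far. The expectation is therefore no step beyond the scatter, estimated as a 1.1-fold lower number from compound 2 to compound 3 (0.02 log units; within the scatter). For compound 3 the estimate is 400 nM, with a range from 130 nM to 1300 nM.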

Compound 3, half-maximal inhibitory concentration: 380 nM
For compound 3 the middle estimate is 1.1-fold (0.02 log units) above the measured one; low and high end bracket the measured number.
By their numbers in this assay, from the lowest: compounds 3, 2 and 1 (each within the scatter of the next).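

In this assay the saturated chain carbon, four bonds along the chain from a carbonyl carbon, now carries an aromatic ring as well as plain chains: phenyl in place of pentyl gives a 1.1-fold lower number from compound 2 to compound 3 (0.04 log units; within the scatter) and phenyl in place of propyl gives a 1.1-fold lower number from compound 1 to compound 3 (0.05 log units; within the scatter). Among these compounds, earlier, the only variation was in the length of a chain, so these are the first steps to show that exchanging a chain for one six-membered aromatic ring of carbon only leaves the number within the scatter, and compounds 1, 2 and 3 cannot be separated in this assay. Nothing available explains this flat result, which stands as an observation only.

As far as these compounds go, every group exchanged so far consists of carbon alone, so it remains open whether an amine, a carboxylic acid or a ring containing nitrogen at this place would give a step beyond the scatter. From the compounds shown here alone, a longer chain is also open, as is any change to the hydroxamic acid or the anilide end of the shared core.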